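A few compounds are considered here, and "the series" means these few. Any claim that something is new, unique, unknown or untested is made for them only; others in the source may bear on it.

Measured compounds in an assay on isolated protein for inhibition of Aromatase (Homo sapiens), read by ELISA, using NADPH, with a stated time of 24 h; on this read-out lower numbers stand for stronger inhibition and higher numbers for weaker inhibition:

Compound 1, `Fc1ccc2c(Cn3ccnc3)c(-c3ccc(Cl)cc3)[nH]c2c1`: 82.9 nM
Compound 2, `Fc1ccc(-c2[nH]c3cc(Cl)ccc3c2Cn2ccnc2)cc1`: 32.3 nM
Compound 3, `COc1ccc(-c2[nH]c3cc(F)ccc3c2Cn2ccnc2)cc1`: 36.1 nM

Compound 2 stands at the lowest number of the three. Compound 3 sits next to it within the scatter, so no order between compound 2 and compound 3 is claimed; compound 1 lies beyond the scatter from compound 2. Compound 1 and compound 2 share the same atoms joined differently, and the difference between the two cores is not broken down here.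

One change has a measured step. From compound 1 to compound 3 the change is methoxy in place of chloro on an aromatic carbon and it gives a 2.3-fold lower number from compound 1 to compound 3 (0.36 log units; beyond the scatter), a modest improvement beyond the scatter.

The unmeasured compound 4, `COc1ccc2c(Cn3ccnc3)c(-c3ccc(F)cc3)[nH]c2c1`, derives from compound 2 by methoxy in place of chloro on an aromatic carbon. This is the same kind of change as that from compound 1 to compound 3, not the same: in compound 3 the methoxy sits on an aromatic carbon of a six-membered aromatic ring of carbon only, para to a large group, whereas in compound 4 it sits on a ring that is part of a fused or bridged system of two rings, meta to a fused ring and para to a fused ring. The measured step therefore carries over only loosely.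

For compound 4 the expected step is a 1.3-fold lower number from compound 2 to compound 4 (0.11 log units; within the scatter), leaning on compound 1 to compound 3 because a 2.3-fold lower number from compound 1 to compound 3 (0.36 log units; beyond the scatter) favoured the methoxy, tempered by the shift in place. Compound 4 is thus estimated at 25 nM in this assay, with an expected range from 10 nM to 65 nM.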

Compound 4, half-maximal inhibitory concentration: 109 nM
For compound 4 the middle estimate is 4.4-fold (0.64 log units) below the measured one; measured number above the stated range.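

In this assay, methoxy in place of chloro on an aromatic carbon of the ring that is part of a fused or bridged system of two rings gives a 3.4-fold higher number from compound 2 to compound 4 (0.53 log units; beyond the scatter) and so weakens inhibition. Set beside the earlier step, where the same exchange fell on the other six-membered aromatic ring, the change does not carry from one core to the other in either direction or size: the same change on two cores in this assay, a 2.3-fold lower number (0.36 log units; beyond the scatter) from compound 1 to compound 3 and a 3.4-fold higher number (0.53 log units; beyond the scatter) from compound 2 to compound 4, 7.7-fold (0.89 log units) apart, beyond the scatter of two such steps

Within the data shown here, this shows that a gain from methoxy on one core cannot be assumed on the other, but with only two steps it gives no rule, and the place of the exchange differs together with the rest of the core, so the two influences cannot be separated and no cause can be assigned.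

The compounds shown carry only chloro, fluoro and methoxy on these rings, which leaves open how a nitrile, an amine or a carboxylic acid would read at the same places. Also open, going by these compounds, is whether the opposite steps would persist with the methoxy exchange repeated at each place on a single core.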